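The source may hold more compounds than are shown below. What is called first, only, known or untested is meant among the compounds shown, and "the series" means these compounds.

In a functional assay on CAPAN-1 cells (Homo sapiens) for antiproliferative activity, with a stated time of 72 h (a higher number here means a weaker inhibitor, a lower number a stronger inhibitor), compound 1 (`Nc1ncnn2c([C@@H]3O[C@H](CO)[C@@H](O)[C@H]3O)cc(-c3ccccc3)c12`) gives 65200 nM and compound 2 (`COc1ccc(-c2cc([C@@H]3O[C@H](CO)[C@@H](O)[C@H]3O)n3ncnc(N)c23)cc1`) gives 43900 nM. Within the data shown here, these two values lie within the scatter of each other, so compound 2 stands level with compound 1 on the numbers so far. Compound 3 (`Nc1ncnn2c([C@@H]3O[C@H](CO)[C@@H](O)[C@H]3O)cc(-c3ccccc3Cl)c12`) has not yet been measured. It carries 2-chlorophenyl in place of 4-methoxyphenyl on an aromatic carbon of a five-membered aromatic ring with 1 nitrogen: 2-chlorophenyl in place of 4-methoxyphenyl on an aromatic carbon. Among the measured compounds shown here, only one measured step bears on this change: a 1.5-fold lower number from compound 1 to compound 2 (0.17 log units; within the scatter), with methoxy in place of hydrogen on the same aromatic group. For the measured compounds named here, no measured step shows what chlorine does here, so the expectation is weakly founded. Given that small step, no change beyond the scatter is expected in this assay. The expected step is a 1.0-fold higher number from compound 2 to compound 3 (0.01 log units; within the scatter). For compound 3 the estimated value is 45000 nM, with an expected range from 18000 nM to 100000 nM.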

Compound 3, half-maximal inhibitory concentration: 54900 nM
Compound 3: middle estimate off by 1.2-fold (0.09 log units), on the low side; measured number inside the range.
By their numbers in this assay, from the lowest: compounds 2, 3 and 1 (each within the scatter of the next).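

In this assay, neither the exchange of 4-methoxyphenyl for 2-chlorophenyl (a 1.3-fold higher number from compound 2 to compound 3 (0.10 log units; within the scatter)) nor the addition of chloro to the phenyl of compound 1 (a 1.2-fold lower number from compound 1 to compound 3 (0.07 log units; within the scatter)) moves the number beyond the scatter. The earlier compounds shown here showed this only for methoxy; the aromatic carbon of the five-membered aromatic ring with 1 nitrogen now carries phenyl, 4-methoxyphenyl and 2-chlorophenyl with no separation among the three compounds. No measured evidence is available to explain this result.

The compounds shown leave open whether any aryl substituent at this position can shift the number beyond the scatter, since only methoxy and chloro appear here. On these data alone, it also remains open whether an amine or a carboxylic acid on the phenyl, or a longer chain in its place, would do so.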